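Methoxy for bromo on the aniline ring of the thiadiazole series

A few compounds are considered here, and "the series" means these few. Any claim that something is new, unique, unknown or untested is made for them only; others in the source may bear on it.

Of the compounds shown here, three have been measured so far. Compound 1 `COc1ccc(-c2nnc(Nc3ccc(Cl)c(Cl)c3)s2)cc1` gives 4160 nM in an assay on isolated protein for inhibition of beta-glucuronidase (Bos taurus), read by spectrophotometry, with a stated time of 30 min; a higher number here means a weaker inhibitor, a lower number a stronger inhibitor. Compound 3 `Clc1ccc(Nc2nnc(-c3ccc(Br)cc3)s2)cc1Cl` gives 7160 nM in this assay, and compound 2 `Brc1ccc(-c2nnc(Nc3cccc(Br)c3)s2)cc1` gives 17300 nM, the highest of the three numbers; the gap from compound 2 to compound 3 is stated to lie beyond the scatter. The difference between the cores of compound 2 and compound 3 is not broken down here.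

For the measured compounds named here, the one change that is seen twice is the exchange of a halogen for an ether group on the outer ring: methoxy in place of bromo on an aromatic carbon. In measured terms it made a 1.7-fold lower number from compound 3 to compound 1 (0.24 log units; within the scatter), a step within the scatter.

Compound 4 `COc1cccc(Nc2nnc(-c3ccc(Br)cc3)s2)c1` is the not yet measured member. It arises from compound 2 by the same kind of change, not the same: methoxy in place of bromo on an aromatic carbon. The place lines differ in one respect, para to a large group in the first case, meta to a large group in the second.

Going by the values given here, with only one measured example of this change, and that one within the scatter, the step from compound 2 to compound 4 is expected to be small, about a 1.7-fold lower number from compound 2 to compound 4 (0.24 log units; within the scatter) in this assay, resting on the step of a 1.7-fold lower number from compound 3 to compound 1 (0.24 log units; within the scatter) and on the starting value of compound 2 at 17300 nM. Compound 4 is therefore estimated at 10000 nM, with an expected range from 4000 nM to 25000 nM.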

Compound 4, half-maximal inhibitory concentration: 31100 nM
Compound 4: the middle estimate sits 3.1-fold (0.49 log units) below what was measured, outside the stated range (above it).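

Methoxy in place of bromo on an aromatic carbon gives a 1.8-fold higher number from compound 2 to compound 4 (0.25 log units; within the scatter) in this assay, and the two readings of this change do not agree: the same change on two cores in this assay, a 1.7-fold lower number (0.24 log units; within the scatter) from compound 3 to compound 1 and a 1.8-fold higher number (0.25 log units; within the scatter) from compound 2 to compound 4, 3.1-fold (0.49 log units) apart, beyond the scatter of two such steps

Each step taken alone lies within the scatter, and only the gap between them lies beyond it; the change therefore cannot be carried from one core to another in this series as a single fixed step. The data do not show what separates the two readings: the cores differ, and the change stands para to a large group in one pair and meta to a large group in the other, and two pairs cannot tell these apart or predict the direction of the step on a further core.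

Still open, on these data alone, is how the change reads when both places are compared on a single core, which would separate the effect of place from that of the core. Also open is how an amine or a carboxylic acid in the same places would compare with bromo and methoxy, as the compounds shown carry only bromo, chloro and methoxy on their outer rings.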